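Fluorophenyl Placement Across Two Related Series

The source may report more compounds than this note shows. Statements on the series, on what has been measured and on what is new or still open speak of the compounds shown alone.

Three compounds have so far been examined in a functional assay on DU-145 cells (Homo sapiens) for inhibition; on this read-out higher numbers stand for weaker inhibition and lower numbers for stronger inhibition. Compound 1 `Oc1ccccc1-c1cc(-c2ccccc2F)cc(-c2ccccc2O)n1` gives only a limit of the assay, > 50000 nM. Compound 2 `Oc1ccccc1-c1cc(-c2cccc(F)c2)cc(-c2ccccc2O)n1` likewise gives only a limit, > 50000 nM. Within the data shown here, compound 3 `Oc1cccc(-c2cc(-c3ccccc3F)cc(-c3cccc(O)c3)n2)c1` gives 11200 nM, the only number among the three. The change from compound 1 to compound 2, (3-fluorophenyl in place of 2-fluorophenyl on an aromatic carbon), produced a step that the two limits leave unreadable from compound 1 to compound 2, since both values sit at the limit of > 50000 nM in this assay, at which 2 of the 3 values shown sit. How the core of compound 3 differs from the core of compound 1 is not broken down here. Compound 4 `Oc1cccc(-c2cc(-c3cccc(F)c3)cc(-c3cccc(O)c3)n2)c1` carries the same kind of change as compound 2, namely (3-fluorophenyl in place of 2-fluorophenyl on an aromatic carbon), though here the place is meta to two 3-hydroxyphenyl groups rather than meta to two 2-hydroxyphenyl groups. The step that the two limits leave unreadable from compound 1 to compound 2 cannot be read, so it tells neither direction nor size. The step from compound 3 to compound 4 is therefore expected to be modest, a 1.3-fold higher number from compound 3 to compound 4 (0.13 log units; within the scatter), resting only on compound 3 at 11200 nM as an anchor. Compound 4 is accordingly estimated at 15000 nM, with a likely range from 5000 nM to 60000 nM.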

Compound 4, half-maximal inhibitory concentration: 23800 nM
Beside the measured number, compound 4's estimate is 1.6-fold (0.20 log units) below it; the measured number falls inside the stated range.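

On the core carrying two 3-hydroxyphenyl groups, 3-fluorophenyl in place of 2-fluorophenyl gave a 2.1-fold higher number from compound 3 to compound 4 (0.33 log units; beyond the scatter) in this assay, a modest step towards weaker inhibition that only just clears the usual scatter. On the core of compound 1, the same change cannot be read, because compound 1 and compound 2 each give only a limit of the assay and no number: the limit of > 50000 nM in this assay, at which 2 of the 4 values shown sit. The result therefore shows what the change does on one core, but it does not show that the change carries over, since a single readable step cannot establish a shared direction or size across the two cores.

The compounds shown leave open what happens on either core when the fluorophenyl group gives way to a plain phenyl, or to a different kind of group such as an amine or a carboxylic acid. They also leave open whether a methoxy group in place of the hydroxyl groups would shift the read-out.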